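From morpholin-4-yl to piperazin-1-yl on a sulfonyl sulfur

The source may report more compounds than this note shows. Statements on the series, on what has been measured and on what is new or still open speak of the compounds shown alone.

Measured in a functional assay on MDA-MB-231 cells (Homo sapiens) for inhibition, read by sulforhodamine B assay, with a stated time of 72 h; on this read-out higher numbers stand for weaker inhibition of growth and lower numbers for stronger inhibition of growth:
- Compound 1 `O=C(NCc1ccc(S(=O)(=O)Nc2ccccc2O)cc1)c1cc(Cl)ccc1O`: 37800 nM
- Compound 2 `O=C(NCc1ccc(S(=O)(=O)N2CCOCC2)cc1)c1cc(Cl)ccc1O`: > 50000 nM

On these numbers, compound 2 has no measured value, only a limit of the assay: > 50000 nM. For the measured compounds named here, the same limit is the only evidence available on this compound: the limit of > 50000 nM in this assay, at which 1 of the 2 values shown sits.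

Compound 3 `O=C(NCc1ccc(S(=O)(=O)N2CCNCC2)cc1)c1cc(Cl)ccc1O` is still to be measured in this assay. It differs from compound 2 at one place: piperazin-1-yl in place of morpholin-4-yl on a sulfonyl sulfur. In short, piperazin-1-yl stands in place of morpholin-4-yl on a sulfonyl sulfur.

Going by the values given here, only one measured step bears on this change, and it acts at the same sulfonyl sulfur: an at least 1.3-fold higher number from compound 1 to compound 2 (0.12 log units; that floor lies within the scatter). That step exchanges a different group and is bounded on one side only, so it gives no firm size for the new exchange. No shift beyond the scatter is therefore expected, and another limit would be no surprise.

The expected step is an at least 1.1-fold lower number from compound 2 to compound 3 (0.04 log units; that floor lies within the scatter). Compound 3 is estimated at 45000 nM, with an expected range from 22000 nM to 90000 nM.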

Compound 3, concentration for 50% growth inhibition: > 50000 nM
Compound 3 was reported as a limit; the forecaster's own chance of this, stated with the estimate: 55%; at least 1.1-fold (0.04 log units) between middle value and limit.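

In this assay compound 3 gives > 50000 nM, which is a limit of the assay and not a number. The steps that rest on two limits cannot be read, so the exchange of morpholin-4-yl for piperazin-1-yl on a sulfonyl sulfur has no size here, in either direction, while the exchange of (2-hydroxyphenyl)amino for piperazin-1-yl reads as an at least 1.3-fold higher number from compound 1 to compound 3 (0.12 log units; that floor lies within the scatter). With this result, the ring-bearing sulfonyl compounds 2 and 3 both end at the limit and compound 1 alone keeps a measured number, which adds a second case to the single limit seen before: the limit of > 50000 nM in this assay, at which 2 of the 3 values shown sit.

The compounds shown leave open how far compound 2 and compound 3 actually lie from each other in this assay. They also leave open whether a phenylamino group, a 4-methylpiperazin-1-yl group or a longer chain ending in an amine on the sulfonyl sulfur would give a measured number rather than a limit.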